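A few compounds are considered here, and "the series" means these few. Any claim that something is new, unique, unknown or untested is made for them only; others in the source may bear on it.

Compound 1 `O=C(N/N=C/c1ccccn1)c1cccc(S(=O)(=O)N2CCOCC2)c1` gives 88100 nM in a functional assay on PC-3 cells (Homo sapiens) for antiproliferative activity, read by MTT assay, with a stated time of 72 h; a lower number here means a stronger inhibitor, a higher number a weaker inhibitor.
Compound 2 `CCOc1cccc(/C=N/NC(=O)c2cccc(S(=O)(=O)N3CCOCC3)c2)c1O` gives 15300 nM in this assay.

For the measured compounds named here, of these two, compound 2 carries the lower number, and the single measured step, a 5.8-fold lower number from compound 1 to compound 2 (0.76 log units; beyond the scatter), is the only guide available. Compound 3 `O=C(N/N=C/c1cc(Cl)ccc1O)c1cccc(S(=O)(=O)N2CCOCC2)c1` differs from compound 2 in one respect: 5-chloro-2-hydroxyphenyl in place of 3-ethoxy-2-hydroxyphenyl on a carbon with a double bond to nitrogen. Going by the values given here, no measured step makes this kind of exchange, and the one known step changed a different group, so the direction of the change cannot be read from the data. Compound 3 is therefore expected to stay near compound 2, with an estimated step of a 1.3-fold higher number from compound 2 to compound 3 (0.12 log units; within the scatter), giving an estimate of 20000 nM in this assay, within a range from 6000 nM to 65000 nM.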

Compound 3, half-maximal inhibitory concentration: 10500 nM
Beside the measured number, compound 3's estimate is 1.9-fold (0.28 log units) above it; measured number inside the range.
By their numbers in this assay, from the lowest: compounds 3 and 2 (each within the scatter of the next); then compound 1.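

Across the two hydroxyphenyl groups, the exchange at this carbon gives a 1.5-fold lower number from compound 2 to compound 3 (0.16 log units; within the scatter) in this assay, so 5-chloro-2-hydroxyphenyl and 3-ethoxy-2-hydroxyphenyl cannot be told apart here. The step of an 8.4-fold lower number from compound 1 to compound 3 (0.92 log units; beyond the scatter) shows that a second hydroxyphenyl group also stands clear of pyridin-2-yl, so that earlier gap was not tied to the 3-ethoxy-2-hydroxyphenyl group alone.

Still open, on these data alone, is how a hydroxyphenyl group carrying an amine or a carboxylic acid in place of the chlorine would compare, and whether the hydroxy group itself matters. Nothing measured here bears on the reason for these numbers.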